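A few compounds are considered here, and "the series" means these few. Any claim that something is new, unique, unknown or untested is made for them only; others in the source may bear on it.

Compound 1 `CN(C)c1ccc(C2CC(c3cc4ccccc4o3)=NN2C(=O)c2ccncc2)cc1`: in an ADME assay on Vero cells (Chlorocebus sabaeus) for cytotoxicity, read by MTT assay, with a stated time of 72 h (a higher number here means a weaker inhibitor, a lower number a stronger inhibitor), compound 1 gives > 210000 nM, a limit.
Compound 2 `O=C(c1ccncc1)N1N=C(c2cc3ccccc3o2)CC1/C=C/c1ccccc1`: in this assay compound 2 gives > 212000 nM, a limit.
Compound 3 `CCn1cc(C(=O)N2N=C(c3cc4ccccc4o3)CC2c2ccccc2OC)c(=O)c2ccc(C)nc21`: in this assay compound 3 gives > 187000 nM, a limit.

All three values are limits of this assay, so none of them is a number. For the measured compounds named here, the only one-place step among the measured compounds, a step that the two limits leave unreadable from compound 1 to compound 2, cannot be read for the same reason. Compound 3 stands at the limit of > 187000 nM in this assay, at which 1 of the 3 values shown sits; the other two compounds sit at the limit of > 210000 nM in this assay, at which 1 of the 3 values shown sits, and (the limit of > 212000 nM in this assay, at which 1 of the 3 values shown sits), and the three limits lie within the scatter of one another.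

Compound 4 `CCn1cc(C(=O)N2N=C(c3cc4ccccc4o3)CC2c2ccc(OC)cc2O)c(=O)c2ccc(C)nc21` differs from compound 3 by 2-hydroxy-4-methoxyphenyl in place of 2-methoxyphenyl on a saturated ring carbon, a 2-hydroxy-4-methoxyphenyl in place of 2-methoxyphenyl on a saturated ring carbon. Going by the values given here, no measured step bears on this change, and no measured step in this assay has a readable size at all. The step from compound 3 to compound 4 is therefore expected to show nothing beyond the scatter, a step that the limit leaves unreadable from compound 3 to compound 4, because compound 3 sits at the limit of > 187000 nM in this assay, at which 1 of the 3 values shown sits, and every value in this assay is a limit. Compound 4 is expected to give 200000 nM in this assay, with a range from 100000 nM to 400000 nM, most likely again as a limit.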

Compound 4, half-maximal inhibitory concentration: > 154000 nM
Compound 4: no number, only a limit; the forecaster's own chance of this, stated with the estimate: 85%; the middle value does not contradict the limit.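

In this assay compound 4 gives > 154000 nM, a limit and not a number. Compound 3 also stands only as a limit, and the step between compound 3 and compound 4 cannot be read. The compounds shown leave open what size any change on the shared core has in this assay.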